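Bromo to methoxy on the pendant aryl of compound 2

This account rests on a few compounds, and the source may have more. Where it says the series, first, only, none or still open, it means among the compounds named here.

Compound 2 `COc1cc(C2CC(c3ccc(Br)cc3)=NN2C(C)=O)ccc1OCc1cn(Cc2ccc([N+](=O)[O-])cc2)nn1` stands highest of the two numbers at hand: in a functional assay on COLO 205 cells (Homo sapiens) for inhibition, read by sulforhodamine B assay, tested at 10 uM (a lower number here means less inhibition of growth, a higher number more inhibition of growth at the concentration tested), compound 2 gives 26%. Within the data shown here, its nearest neighbour is compound 1 `COc1ccc(C2CC(c3ccc(OCc4cn(Cc5ccc([N+](=O)[O-])cc5)nn4)cc3)=NN2C(C)=O)cc1`, which in this assay gives 4%, a gap beyond the usual scatter; the two differ in more than one place, so no single step connects them. Compound 3 `COc1ccc(C2=NN(C(C)=O)C(c3ccc(OCc4cn(Cc5ccc([N+](=O)[O-])cc5)nn4)c(OC)c3)C2)cc1` has not yet been measured in this assay. It differs from compound 2 in one place: methoxy in place of bromo on an aromatic carbon, para to a large group. Compound 1 also carries a 4-methoxyphenyl and sits low in this assay, so the bromo of compound 2 may be linked to its higher reading. On that basis a decrease in this assay is expected, and the step of a number 14 percentage points lower from compound 2 to compound 3 (beyond the scatter) is the estimate. Compound 3 is therefore expected to give about 12% in this assay, within a range of 0% to 30%.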

Compound 3, percent growth inhibition at one concentration: 10%
Beside the measured number, compound 3's estimate is 2 percentage points above it, and the stated range covers the measured number.
By their numbers in this assay, from the lowest: compounds 1 and 3 (each within the scatter of the next); then compound 2.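

In this assay, among these compounds, the change from 4-bromophenyl to 4-methoxyphenyl gives the first reading of a single-place change: a number 16 percentage points lower from compound 2 to compound 3 (beyond the scatter). Compounds 1 and 2 differ in more than one place, so their gap could not be assigned to any one group, whereas this pair places a difference beyond the scatter at this aromatic carbon, with the rest of the structure unchanged. Nothing at hand bears on why the reading changes with this swap.

From the compounds shown here alone, it remains open whether the higher reading of compound 2 is specific to bromo, since only bromo and methoxy are compared at this place, and a chloro, an amine or a carboxylic acid there could read differently. This rests on one pair, so it is also unknown whether the same swap would give a similar step on another member of the series.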